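This account rests on a few compounds, and the source may have more. Where it says the series, first, only, none or still open, it means among the compounds named here.

Working notes on the series in an ADME assay on HepG2 cells (Homo sapiens) for cytotoxicity, read by resazurin assay, with a stated time of 24 h; a lower number here means a stronger inhibitor, a higher number a weaker inhibitor.

Compound 1 `Cc1[nH]c2ccc(Cl)cc2c(=O)c1-c1ccc(Oc2ccc(OC(F)(F)F)cc2)cc1` carries the shared core with a diaryl ether side chain. In this assay compound 1 gives > 10000 nM, which is a limit of the assay and not a number. Compound 2 `COc1cc2[nH]c(C)c(-c3ccc(Oc4ccc(OC(F)(F)F)cc4)cc3)c(=O)c2cc1Cl` differs from compound 1 by methoxy in place of hydrogen on an aromatic carbon. In this assay compound 2 gives > 10000 nM, again a limit. The step that the two limits leave unreadable from compound 1 to compound 2 therefore cannot be read.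

Compound 3 `Cc1[nH]c2ccc(Cl)cc2c(=O)c1-c1ccc(Oc2ccc(OC(F)(F)F)cc2)nc1` has a different core; how the two cores differ is not broken down here. In this assay compound 3 gives > 10000 nM, also a limit.

Compound 4 `COc1cc2[nH]c(C)c(-c3ccc(Oc4ccc(OC(F)(F)F)cc4)nc3)c(=O)c2cc1Cl` is not yet measured; it differs from compound 3 by methoxy in place of hydrogen on an aromatic carbon, the same change as from compound 1 to compound 2. All measured values sit at the limit of > 10000 nM in this assay, at which 3 of the 3 values shown sit.

The step is expected to be a step that the limit leaves unreadable from compound 3 to compound 4. This expectation rests on compound 1, whose value > 10000 nM is a limit. It rests likewise on compound 2, whose value > 10000 nM is a limit. Compound 4 is estimated at 20000 nM, between 10000 nM and 60000 nM, most likely reported as a limit.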

Compound 4, half-maximal inhibitory concentration: > 10000 nM
Compound 4: only a limit was reported (the forecaster's own chance of this, stated with the estimate: 85%); the middle value lies beyond the limit too.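

In this assay compound 4 gives > 10000 nM, which is a limit and not a number, so the step from compound 3 to compound 4 cannot be read. The compounds shown leave open whether methoxy in place of hydrogen on an aromatic carbon changes the value at all, and where any of compounds 1 to 4 truly stands: the limit of > 10000 nM in this assay, at which 4 of the 4 values shown sit.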